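Swapping an Aniline Ring for an Indole

A few compounds are considered here, and "the series" means these few. Any claim that something is new, unique, unknown or untested is made for them only; others in the source may bear on it.

Of the compounds shown here, three sharing one core have been tested in a functional assay on A549 cells (Homo sapiens) for inhibition, read by CCK-8 assay, with a stated time of 48 h; a lower number here means a stronger inhibitor, a higher number a weaker inhibitor. Compound 1 `COc1ccc(-c2cc3nccc(-c4cc(OC)c(OC)c(OC)c4)n3n2)cc1N` gives 138 nM, the lowest number of the three. Compound 2 `COc1cc(-c2ccnc3cc(-c4ccc5cc[nH]c5c4)nn23)cc(OC)c1OC` gives 170 nM, and compound 3 `COc1ccc(-c2cc3nccc(-c4cc(OC)c(OC)c(OC)c4)n3n2)cc1F` gives 545 nM. The step of a 1.2-fold higher number from compound 1 to compound 2 (0.09 log units; within the scatter) shows that compound 1 and compound 2 cannot be told apart, while the steps of a 3.9-fold higher number from compound 1 to compound 3 (0.60 log units; beyond the scatter) and a 3.2-fold higher number from compound 2 to compound 3 (0.51 log units; beyond the scatter) set compound 3 apart as the weaker of the group.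

Compound 4 `COc1cc(-c2ccnc3cc(-c4c[nH]c5ccccc45)nn23)cc(OC)c1OC` has not yet been measured. It differs from compound 1 in one place: 1H-indol-3-yl in place of 3-amino-4-methoxyphenyl on an aromatic carbon. The step that bears most directly on this change is a 1.2-fold higher number from compound 1 to compound 2 (0.09 log units; within the scatter), where an indole also replaced the 3-amino-4-methoxyphenyl group and the number barely moved. Going by the values given here, the indole in compound 4 is joined through a different carbon, and no measured pair tells how much that matters, so the outcome could drift by about the size seen in a 3.9-fold higher number from compound 1 to compound 3 (0.60 log units; beyond the scatter). On balance, compound 4 is expected to land close to compound 1, with the step of a 1.7-fold higher number from compound 1 to compound 4 (0.22 log units; within the scatter) estimated to be small. The estimate for compound 4 in this assay is 230 nM, expected to fall between 90 nM and 650 nM.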

Compound 4, half-maximal inhibitory concentration: 29 nM
Compound 4: middle estimate off by 7.9-fold (0.90 log units), on the high side; measured number outside the range, below it.
By their numbers in this assay, from the lowest: compound 4; then compounds 1 and 2 (each within the scatter of the next); then compound 3.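

The point at which the indole is joined matters on this aromatic carbon: going from 1H-indol-6-yl to 1H-indol-3-yl gives a 5.9-fold lower number from compound 2 to compound 4 (0.77 log units; beyond the scatter), so these two indoles are not interchangeable, and the earlier match between compound 1 and compound 2 holds only for 1H-indol-6-yl. The 1H-indol-3-yl group also improves on both substituted phenyl rings, with a 4.8-fold lower number from compound 1 to compound 4 (0.68 log units; beyond the scatter) when it replaces 3-amino-4-methoxyphenyl and a 19-fold lower number from compound 3 to compound 4 (1.27 log units; beyond the scatter) when it replaces 3-fluoro-4-methoxyphenyl, which makes compound 4 the strongest of the four, with all of its steps beyond the scatter. No measurement at hand explains why the point of attachment has such an effect.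

On these data alone, how a 1H-indol-5-yl group, or a 1-methyl-1H-indol-3-yl group with a methyl on the ring nitrogen, would behave at this position remains open. All of these comparisons rest on this assay alone, so whether the same order would hold on other cells is also unknown.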